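The source may report more compounds than this note shows. Statements on the series, on what has been measured and on what is new or still open speak of the compounds shown alone.

Of the compounds shown here, three that share one core have been tested in a functional assay on HUVEC cells (Homo sapiens) for inhibition (a higher number here means a weaker inhibitor, a lower number a stronger inhibitor), and they differ in the group on a carbonyl carbon. Compound 1 `COc1cc(/C=C/C(=O)c2cccc(NC(=O)c3ccc(Cl)cc3)c2)ccc1O`, with 4-chlorophenyl there, gives 0.76 ug/mL. Compound 2 `COc1cc(/C=C/C(=O)c2cccc(NC(=O)c3ccc(Cl)c(Cl)c3)c2)ccc1O`, with 3,4-dichlorophenyl, gives 2.97 ug/mL. Compound 3 `COc1cc(/C=C/C(=O)c2cccc(NC(=O)C(C)C)c2)ccc1O`, with isopropyl, gives 1.44 ug/mL. Its nearer neighbour is reached by a 1.9-fold higher number from compound 1 to compound 3 (0.28 log units; within the scatter), which lies within the scatter, while a 2.1-fold lower number from compound 2 to compound 3 (0.31 log units; beyond the scatter) lies just beyond it.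

Compound 4 `COc1cc(/C=C/C(=O)c2cccc(NC(=O)c3ccccc3)c2)ccc1O` has phenyl in place of isopropyl on a carbonyl carbon. Among the measured compounds shown here, no measured compound carries this unsubstituted phenyl, so the nearest evidence comes from the two chlorinated rings. The two steps between those rings and isopropyl give no single answer, since one stays within the scatter and the other is modest. For the measured compounds named here, the only step on the ring itself, a 3.9-fold higher number from compound 1 to compound 2 (0.59 log units; beyond the scatter), is chloro in place of hydrogen on an aromatic carbon, and it is also modest. Nothing here therefore points to a large change in this assay, and no step beyond the scatter is expected. The expected size is a 1.3-fold lower number from compound 3 to compound 4 (0.12 log units; within the scatter). For compound 4 the estimated value is 1.1 ug/mL, with an expected range from 0.45 ug/mL to 2.8 ug/mL.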

Compound 4, half-maximal inhibitory concentration: 0.37 ug/mL
Beside the measured number, compound 4's estimate is 3.0-fold (0.47 log units) above it; the whole stated range lies above it.
By their numbers in this assay, from the lowest: compound 4; then compounds 1 and 3 (each within the scatter of the next); then compound 2.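

Unsubstituted phenyl on this carbonyl carbon gives the strongest inhibitor of the four in this assay. Its steps to every other compound lie beyond the scatter (a 3.9-fold lower number from compound 3 to compound 4 (0.59 log units; beyond the scatter); a 2.1-fold lower number from compound 1 to compound 4 (0.31 log units; beyond the scatter); an 8.0-fold lower number from compound 2 to compound 4 (0.90 log units; beyond the scatter)). The earlier compounds shown here left it unclear whether a ring here did better than isopropyl, and the answer now depends on the ring: plain phenyl gives a lower number than isopropyl, whereas 4-chlorophenyl stays within the scatter of isopropyl and 3,4-dichlorophenyl gives a higher number. Among the three rings the number rises with each chloro, so in these compounds the chloro groups go with weaker inhibition rather than stronger, although nothing available explains this order.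

Only chloro has been shown on this ring, so a fluoro, methoxy or amino group there could follow the same trend or break it. On the aliphatic side isopropyl stands alone, which leaves open how a longer chain, such as n-butyl, or a saturated ring, such as cyclohexyl, would compare with phenyl.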